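The source may report more compounds than this note shows. Statements on the series, on what has been measured and on what is new or still open speak of the compounds shown alone.

The study sets out from compound 1 `CNc1nc(NC2(C#N)CCCCC2)nc(N2CCCC2)n1`. In an in vitro assay on Sf21 cells for inhibition of high affinity 3',5'-cyclic-AMP phosphodiesterase 7A (Homo sapiens) (on this read-out lower numbers stand for stronger inhibition and higher numbers for weaker inhibition), compound 1 gives > 5000 nM, which is a limit of the assay rather than a number. Compound 2 `CNc1nc(Nc2ccccc2)nc(NC2(C#N)CCCCC2)n1` carries anilino in place of pyrrolidin-1-yl on an aromatic carbon. In this assay compound 2 gives > 5000 nM, again a limit of the assay and not a number. The step that the two limits leave unreadable from compound 1 to compound 2 therefore cannot be sized, because both values rest at the limit of > 5000 nM in this assay, at which 2 of the 2 values shown sit. For the measured compounds named here, compound 2 thus stands at the limit, and the only other value shown beside it is a limit too. Compound 3 `CNc1nc(NC2(C#N)CCCCC2)nc(C2CC2)n1` differs from compound 2 in one place: cyclopropyl in place of anilino on an aromatic carbon. Going by the values given here, the single measured step bears on this change only by showing that the assay returned no number for either compound; it carries no direction and no size forward. For compound 3 the expected step is therefore a step that the limit leaves unreadable from compound 2 to compound 3, of no readable direction beyond the scatter. Compound 3 is accordingly estimated at 8000 nM, within 1500 nM to 40000 nM, with a fair chance that this assay again returns only a limit.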

Compound 3, half-maximal inhibitory concentration: 539 nM
Beside the measured number, compound 3's estimate is 15-fold (1.17 log units) above it; the measured number lies below the stated range.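

In this assay, the group on this aromatic carbon, between two ring nitrogen atoms and opposite the ring nitrogen, now proves able to move the read-out: cyclopropyl in place of anilino gives an at least 9.2-fold lower number from compound 2 to compound 3 (0.96 log units; beyond the scatter), and cyclopropyl in place of pyrrolidin-1-yl gives an at least 9.2-fold lower number from compound 1 to compound 3 (0.96 log units; beyond the scatter). For the compounds shown here, compound 1 and compound 2 could not show this on their own, as the one step between them carried neither direction nor size. Both new steps give only a minimum size, because each starts from a compound that rests at a limit of the assay, not at a number: the limit of > 5000 nM in this assay, at which 2 of the 3 values shown sit.

The compounds shown leave open which difference carries the step, since cyclopropyl, with 3 heavy atoms and 0 hydrogen-bond donors, differs from anilino, with 7 heavy atoms and 1 hydrogen-bond donor, in ring, size and donor count all at once, and it joins the aromatic carbon through carbon, not through nitrogen. On these data alone, whether an isopropyl group, a cyclobutyl ring or a small amine such as dimethylamino at this place would give a number like that of compound 3 also remains open.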